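From 4-methoxyphenyl to 2-methylphenyl in a narrow series

The compounds below may be only part of what the source reports. "The series", "measured", "known", "first", "only" and "open" are said of these compounds alone.

In a functional assay on MDA-MB-231 cells (Homo sapiens) for inhibition, read by MTT assay, with a stated time of 72 h (a higher number here means a weaker inhibitor, a lower number a stronger inhibitor), compound 3 `COc1ccc(-n2cc(COc3cc(C)ccc3C(C)C)nn2)cc1` gives 45300 nM. Compound 1 `Cc1ccc(C(C)C)c(OCc2cn(-c3ccc(O)cc3)nn2)c1` gives 30500 nM, and compound 2 `Cc1ccc(C(C)C)c(OCc2cn(-c3ccccc3Cl)nn2)c1` gives 26600 nM. All three values lie within the scatter of one another, so these numbers do not separate compound 3 from the other two.

Compound 4 `Cc1ccc(C(C)C)c(OCc2cn(-c3ccccc3C)nn2)c1` carries 2-methylphenyl in place of 4-methoxyphenyl on an aromatic nitrogen, a change counted as 2-methylphenyl in place of 4-methoxyphenyl on an aromatic nitrogen. The closest evidence is a 1.7-fold higher number from compound 2 to compound 3 (0.23 log units; within the scatter), which exchanged 2-chlorophenyl for 4-methoxyphenyl on that nitrogen. Two further steps also bear on the question: a 1.1-fold lower number from compound 1 to compound 2 (0.06 log units; within the scatter), with 2-chlorophenyl in place of 4-hydroxyphenyl, and a 1.5-fold higher number from compound 1 to compound 3 (0.17 log units; within the scatter), with methyl in place of hydrogen on an oxygen on an aromatic ring. All three stayed within the scatter. Among the compounds with values here, no measured compound carries 2-methylphenyl, so the entering group itself remains untested.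

With no change among these three compounds reaching beyond the scatter, none is expected here. The estimated step is a 1.4-fold lower number from compound 3 to compound 4 (0.14 log units; within the scatter), which is expected to remain within the scatter. For compound 4 the expected value is 33000 nM, with an estimated range from 17000 nM to 62000 nM.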

Compound 4, half-maximal inhibitory concentration: 10500 nM
Compound 4: middle estimate off by 3.1-fold (0.50 log units), on the high side; the whole stated range lies above it.
By their numbers in this assay, from the lowest: compound 4; then compounds 2, 1 and 3 (each within the scatter of the next).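

In this assay the group on the aromatic nitrogen now makes a readable difference, which none of the earlier exchanges there did: a 4.3-fold lower number from compound 3 to compound 4 (0.63 log units; beyond the scatter) with 2-methylphenyl in place of 4-methoxyphenyl, and a 2.9-fold lower number from compound 1 to compound 4 (0.46 log units; beyond the scatter) with 2-methylphenyl in place of 4-hydroxyphenyl. The most closely matched step is a 2.5-fold lower number from compound 2 to compound 4 (0.40 log units; beyond the scatter) with methyl in place of chloro on an aromatic carbon, so a single exchange of that one group separates two otherwise identical compounds beyond the scatter. All three steps are modest, yet each lies beyond the scatter, which makes compound 4 the strongest inhibitor of the four, and nothing available accounts for this result.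

The compounds shown leave open whether the methyl group is itself the best choice at this place, since they do not tell how an ethyl group, an amine or a carboxylic acid in its stead would read. They also leave open whether a phenyl ring with no added group would read closer to compound 4 or to compound 2.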